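The source may report more compounds than this note shows. Statements on the series, on what has been measured and on what is new or still open speak of the compounds shown alone.

Measured so far in a physicochemical assay for solubility, measured as kinetic solubility; on this read-out higher numbers stand for higher solubility and lower numbers for lower solubility:
compound 1, `Cc1cc(C)c(CN2CCc3c(Cl)cc([C@@H](CO)[C@@H]4CCCO4)c(Cl)c3C2=O)c(=O)[nH]1`, gives 550000 nM;
compound 2, `COC(c1cc(Cl)c2c(c1Cl)C(=O)N(Cc1c(C)cc(C)[nH]c1=O)CC2)C1CCN(C2COC2)CC1`, gives 523000 nM; 519000 nM (2 entries).

Compound 1 holds the only single number shown for it in this assay; one further entry for it carries no single number. Compound 2 has several entries, gathered in the several entries of compound 2 in this assay, 523000 nM; 519000 nM (2 entries), and they sit close to the value of compound 1, within the usual scatter. For the measured compounds named here, no step between two measured compounds that differ in one place is available, so the change leading to compound 3 has no direct precedent here. Compound 3, `Cc1cc(C)c(CN2CCc3c(Cl)cc(-c4c(C)noc4C)c(Cl)c3C2=O)c(=O)[nH]1`, differs from compound 1 in this way: a group of 7 heavy atoms (5 carbon, 1 nitrogen, 1 oxygen; one five-membered aromatic ring with 2 hetero atoms) in place of a group of 8 heavy atoms (6 carbon, 2 oxygen; one five-membered non-aromatic ring with 1 hetero atom), on an aromatic carbon. In this assay a small step downward is expected, one that may not exceed the usual scatter. Compound 3 is estimated at 300000 nM, with a range from 100000 nM to 550000 nM, meaning an expected step of a 1.8-fold lower number from compound 1 to compound 3 (0.26 log units; within the scatter).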

Compound 3, solubility: 93000 nM
Compound 3: the middle estimate sits 3.2-fold (0.51 log units) above what was measured, outside the stated range (below it).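

Exchanging the group with the five-membered non-aromatic ring for 3,5-dimethyl-1,2-oxazol-4-yl, on this aromatic carbon, gives in this assay a 5.9-fold lower number from compound 1 to compound 3 (0.77 log units; beyond the scatter). For the compounds shown here, this is the first one-place step available, and it shows that the group at this position can shift the read-out beyond the scatter. The step also stands clear of the close agreement between repeated readings of one compound: the several entries of compound 2 in this assay, 523000 nM; 519000 nM (2 entries)

The change alters several things at once, including the ring type, the hydrogen-bond donor count and the defined stereocentres, and the compounds shown do not separate which of these matters. They also leave open how this assay would respond to an amine, a carboxylic acid or a longer chain on this aromatic carbon.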